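The source may hold more compounds than are shown below. What is called first, only, known or untested is meant among the compounds shown, and "the series" means these compounds.

The compounds here were tested in a functional assay on RKE cells for antagonist activity at Vasoactive intestinal polypeptide receptor 1 (Rattus norvegicus), read by HTRF and cAMP accumulation, with stated times of 10 min and 30 min; a lower number here means a stronger inhibitor, a higher number a weaker inhibitor. Compound 1 `Cc1ccc(-c2cc(C(C)(C)C)cc(C(C)C)c2CO)cc1` gives 300 nM, and compound 2 `CC(C)c1cc(C(C)(C)C)cc(-c2cccc(Cl)c2)c1CO` gives 100 nM. Going by the values given here, the single change between them, a 3.0-fold lower number from compound 1 to compound 2 (0.48 log units; beyond the scatter), is a modest step. Compound 3 `CC(C)CC(=O)Nc1sc2c(c1C#N)CCCC2` rests on a different core and gives 1900 nM, the highest of the three numbers and so the weakest inhibitor shown, with compound 1 nearest to it and compound 2 furthest from it. Compound 4 `N#Cc1c(NC(=O)c2ccccc2)sc2c1CCCC2` differs from compound 3 in one place: phenyl in place of isobutyl on a carbonyl carbon. Among the compounds with values here, no measured step bears directly on this change; the only measured step, a 3.0-fold lower number from compound 1 to compound 2 (0.48 log units; beyond the scatter), concerns a different core and a different kind of position, so it gives no guide to an exchange at a carbonyl carbon. With nothing to point either way, the step from compound 3 to compound 4 is expected to stay within the usual scatter, as a 1.3-fold lower number from compound 3 to compound 4 (0.10 log units; within the scatter). Compound 4 is therefore estimated to give about 1500 nM, within a range from 400 nM to 6000 nM.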

Compound 4, half-maximal inhibitory concentration: 15000 nM
Estimate against measurement, compound 4: 10-fold (1.00 log units) below, outside the stated range (above it).
By their numbers in this assay, from the lowest: compound 2; then compound 1; then compound 3; then compound 4.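

On a carbonyl carbon whose other neighbour is an amide-type nitrogen, the group matters in this assay: phenyl in place of isobutyl gives a 7.9-fold higher number from compound 3 to compound 4 (0.90 log units; beyond the scatter) and so a weaker inhibitor. Going by these compounds alone, this is the first measured sign that this position does not accept every group equally, and here a six-membered aromatic ring of carbon only does worse than a chain with no ring. Nothing measured here accounts for the loss.

With only isobutyl and phenyl shown at this position, it remains open whether the drop follows from having a ring at all or belongs to phenyl alone. A cyclohexyl group, a shorter chain such as ethyl, or a phenyl ring bearing a methoxy group at this carbonyl carbon would help separate those possibilities.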